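This account rests on a few compounds, and the source may have more. Where it says the series, first, only, none or still open, it means among the compounds named here.

Measured in a functional assay on A549 cells (Homo sapiens) for antiproliferative activity, read by MTT assay; a higher number here means a weaker inhibitor, a lower number a stronger inhibitor:
Compound 1 `Cn1c(=O)c(=O)n(C2CCCC2)c2nc(N/N=C/c3cccs3)ncc21`: > 100000 nM (a limit)
Compound 2 `Cn1c(=O)c(=O)n(C2CCCC2)c2nc(N/N=C/c3ccccc3F)ncc21`: 31200 nM
Not yet measured: compound 3 `Cn1c(=O)c(=O)n(C2CCCC2)c2nc(N/N=C/c3ccccc3Cl)ncc21`

Going by the values given here, compound 2, at 31200 nM, holds the only actual number so far. Compound 1 stands at > 100000 nM, which is a limit of the assay and not a number.

Compound 3 differs from compound 2 in one place: chloro in place of fluoro on an aromatic carbon. Chloro takes the place of fluoro on an aromatic carbon, ortho to a large group.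

Among the compounds with values here, only one measured step bears on this, an at least 3.2-fold lower number from compound 1 to compound 2 (0.50 log units; beyond the scatter), and it exchanged a whole ring, thiophen-2-yl for 2-fluorophenyl, starting from a limit. It therefore says little about the size of a swap of one halogen for another, so no change beyond the scatter is expected in this assay.

The expected result is a 1.0-fold lower number from compound 2 to compound 3 (0.02 log units; within the scatter). For compound 3 the estimate is 30000 nM, with an expected range from 12000 nM to 80000 nM.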

Compound 3, half-maximal inhibitory concentration: 9860 nM
Beside the measured number, compound 3's estimate is 3.0-fold (0.48 log units) above it; the whole stated range lies above it.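

In this assay, the exchange of one halogen for another on an aromatic carbon, ortho to a large group, is not silent: a 3.2-fold lower number from compound 2 to compound 3 (0.50 log units; beyond the scatter). This shows that a single atom at this place can move the number beyond the scatter, which the earlier exchange of a whole ring could not show. With 2-chlorophenyl in place of thiophen-2-yl the step reads an at least 10-fold lower number from compound 1 to compound 3 (1.00 log units; beyond the scatter), but the value of compound 1 is a limit and not a number, so the true size of that step stays unknown: the limit of > 100000 nM in this assay, at which 1 of the 3 values shown sits.

Going by these compounds, whether the number would keep falling with bromo or iodo at this place remains open, as does the outcome with methyl or methoxy there. Also open, on these data alone, is how chloro would fare on another carbon of the phenyl ring.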